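The source may hold more compounds than are shown below. What is called first, only, known or untested is meant among the compounds shown, and "the series" means these compounds.

Measured in a functional assay on A549 cells (Homo sapiens) for antiproliferative activity, read by sulforhodamine B assay, with a stated time of 72 h; a lower number here means a stronger inhibitor, a higher number a weaker inhibitor:
- compound 1 `Cc1ccc(S(=O)(=O)Nc2cc(SCCC(=O)N[C@@H](CC(C)C)B(O)O)c(O)c3ccccc23)cc1`: 8190 nM
- compound 2 `CC(C)C[C@H](NC(=O)CCSc1cc(NS(=O)(=O)c2ccccc2)c2ccccc2c1O)B(O)O`: 7800 nM
- compound 3 `CC(C)C[C@H](NC(=O)CCSc1cc(NS(=O)(=O)c2ccc(Cl)cc2)c2ccccc2c1O)B(O)O`: 8100 nM

Compound 3 lies within the scatter of both other compounds: a 1.0-fold lower number from compound 1 to compound 3 (0.00 log units; within the scatter) and a 1.0-fold higher number from compound 2 to compound 3 (0.02 log units; within the scatter). Compound 4 `CC(C)C[C@H](NC(=O)CCSc1cc(NS(=O)(=O)c2cccs2)c2ccccc2c1O)B(O)O` carries thiophen-2-yl in place of 4-chlorophenyl on a sulfonyl sulfur. The measured steps, together with a 1.1-fold lower number from compound 1 to compound 2 (0.02 log units; within the scatter), only exchange methyl, hydrogen and chloro on an aromatic carbon, and none exceeds the scatter. Among the compounds with values here, no measured step replaces the ring itself, so the support is indirect. The expected change in this assay is none beyond the scatter, with an estimated 1.0-fold lower number from compound 3 to compound 4 (0.01 log units; within the scatter). Compound 4 is expected at 8000 nM, with an estimated range of 4500 nM to 14000 nM.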

Compound 4, half-maximal inhibitory concentration: 5930 nM
Estimate against measurement, compound 4: 1.3-fold (0.13 log units) above, within the range that was stated.
By their numbers in this assay, from the lowest: compounds 4, 2, 3 and 1 (each within the scatter of the next).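

In this assay, the group on the sulfonyl sulfur changes here as a whole ring rather than by a substituent, and all three steps stay within the scatter: a 1.4-fold lower number from compound 3 to compound 4 (0.14 log units; within the scatter), a 1.3-fold lower number from compound 2 to compound 4 (0.12 log units; within the scatter) and a 1.4-fold lower number from compound 1 to compound 4 (0.14 log units; within the scatter). Thiophen-2-yl, a five-membered aromatic ring with 1 hetero atom, therefore gives no separation from 4-chlorophenyl, phenyl or 4-methylphenyl at this position. No measurement bears on why these numbers stay together.

Open, on these data alone, is whether a non-aromatic group on the sulfonyl sulfur, such as methyl or cyclohexyl, would give a step beyond the scatter. The same holds for a ring carrying an amine or a carboxylic acid.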